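Shortening the chain to the hydroxycarbamoyl group

The source may hold more compounds than are shown below. What is called first, only, known or untested is meant among the compounds shown, and "the series" means these compounds.

Measured so far:
compound 1 `CC(C)c1cc(-c2n[nH]c(=O)n2-c2cccc(NC(=O)CCCCCC(=O)NO)c2)c(O)cc1O`: 1600 nM
compound 2 `CC(C)c1cc(-c2n[nH]c(=O)n2-c2cccc(NC(=O)CCCCC(=O)NO)c2)c(O)cc1O`: 1600 nM
compound 3 `CC(C)c1cc(-c2n[nH]c(=O)n2-c2ccc(C(=O)NCCCCCC(=O)NO)cc2)c(O)cc1O`: 4600 nM

All three were run in a functional assay on A549 cells (Homo sapiens) for inhibition; on this read-out lower numbers stand for stronger inhibition and higher numbers for weaker inhibition. The step of no change at the digits printed from compound 1 to compound 2 (within the scatter) rests on one change: hydroxycarbamoyl in place of (hydroxycarbamoyl)methyl on a saturated chain carbon, four bonds along the chain from a carbonyl carbon. Compound 3 has the same atoms as compound 1, joined differently; how the two cores differ is not broken down here. Compound 3 stands at the highest number of the three, beyond the scatter from compound 1 and from compound 2.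

Compound 4 `CC(C)c1cc(-c2n[nH]c(=O)n2-c2ccc(C(=O)NCCCCC(=O)NO)cc2)c(O)cc1O` has not yet been measured in this assay. It differs from compound 3 by hydroxycarbamoyl in place of (hydroxycarbamoyl)methyl on a saturated chain carbon, four bonds along the chain from an amide-type nitrogen. This is the same kind of change as from compound 1 to compound 2, though there the place was four bonds along the chain from a carbonyl carbon and here it is four bonds along the chain from an amide-type nitrogen. Because no change at the digits printed from compound 1 to compound 2 (within the scatter) compound 4 is expected to stay close to compound 3, with an estimated step of no change at the digits printed from compound 3 to compound 4 (within the scatter). The estimate for compound 4 is 4600 nM.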

Compound 4, half-maximal inhibitory concentration: 4600 nM
Compound 4: middle estimate and measured number agree at the digits printed; the range from low to high includes it.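

In this assay, hydroxycarbamoyl in place of (hydroxycarbamoyl)methyl gives no change at the digits printed from compound 3 to compound 4 (within the scatter), and the step carries over from one core to the other: the same change on two cores in this assay, no change at the digits printed (within the scatter) from compound 1 to compound 2 and no change at the digits printed (within the scatter) from compound 3 to compound 4, 1.0-fold (0.00 log units) apart, within the scatter of two such steps. On these two cores, the shorter chain leaves the number in place, whether the change lies four bonds along the chain from a carbonyl carbon or from an amide-type nitrogen. This rests on two pairs in one assay and does not show that the same holds on any other core, nor does it explain why the number stays put.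

Going by these compounds, it remains open whether a longer chain would stay equally flat on both cores. On these data alone, it is also open whether a carboxylic acid in place of the hydroxycarbamoyl group would track across them in the same way.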